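The source may hold more compounds than are shown below. What is called first, only, known or untested is meant among the compounds shown, and "the series" means these compounds.

Compound 1 `CCn1c(C(=O)NCCN(C)C)ccc1C(CC)(CC)c1ccc(OCCC(O)(CC)CC)c(C)c1`: 1140 nM
Compound 2 `CCn1c(C(=O)NCC#N)ccc1C(CC)(CC)c1ccc(OCCC(O)(CC)CC)c(C)c1`: > 50000 nM
Compound 3 `C=CCN(C)C(=O)c1ccc(C(CC)(CC)c2ccc(OCCC(O)(CC)CC)c(C)c2)n1CC`: > 50000 nM

For the measured compounds named here, in a functional assay on Caco-2 cells (Homo sapiens) for antiproliferative activity, read by MTT assay, with a stated time of 48 h (on this read-out higher numbers stand for weaker inhibition and lower numbers for stronger inhibition), compound 1 gives 1140 nM, the only real number among the three. For compound 2 the value > 50000 nM is a limit of the assay, not a number. For compound 3 the value > 50000 nM is likewise a limit. Compound 4 `CCC(C)C(NC(=O)c1ccc(C(CC)(CC)c2ccc(OCCC(O)(CC)CC)c(C)c2)n1CC)C(=O)O` differs from compound 1 in one place: 1-carboxy-2-methylbutyl in place of 2-(dimethylamino)ethyl on an amide-type nitrogen. Going by the values given here, two measured steps bear on this, since both also replace the group on that amide-type nitrogen: an at least 43-fold higher number from compound 1 to compound 2 (1.64 log units; beyond the scatter) and an at least 43-fold higher number from compound 1 to compound 3 (1.64 log units; beyond the scatter), each ending at the limit of > 50000 nM in this assay, at which 2 of the 3 values shown sit. Compound 4 is therefore expected to weaken strongly, a 35-fold higher number from compound 1 to compound 4 (1.55 log units; beyond the scatter), with an estimated 40000 nM and a range from 8000 nM to 200000 nM.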

Compound 4, half-maximal inhibitory concentration: 20000 nM
Estimate against measurement, compound 4: 2.0-fold (0.30 log units) above; measured number inside the range.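

In this assay, putting 1-carboxy-2-methylbutyl in place of 2-(dimethylamino)ethyl on this amide-type nitrogen still costs much activity, with an 18-fold higher number from compound 1 to compound 4 (1.24 log units; beyond the scatter). Yet this group does better than the other two replacements, with an at least 2.5-fold lower number from compound 3 to compound 4 (0.39 log units; beyond the scatter) and an at least 2.5-fold lower number from compound 2 to compound 4 (0.39 log units; beyond the scatter). Some activity therefore survives without the dimethylamino group, though it is clearly weakened.

As far as these compounds go, the true gaps to compound 2 and compound 3 stay open because both compounds sit at a limit, not at a number: the limit of > 50000 nM in this assay, at which 2 of the 4 values shown sit. Also open is whether a primary amine or a shorter carboxylic acid chain on this nitrogen would recover more activity.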